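Does fluorine rescue an inactive amide?

A few compounds are considered here, and "the series" means these few. Any claim that something is new, unique, unknown or untested is made for them only; others in the source may bear on it.

Measured in a functional assay on A549 cells (Homo sapiens) for inhibition, read by MTT assay, with a stated time of 48 h; a higher number here means a weaker inhibitor, a lower number a stronger inhibitor:
Compound 1 `O=C(/C=C/c1coc2cc(O)ccc2c1=O)NCc1ccccc1` gives > 100000 nM (a limit)
Compound 2 `COc1ccc2c(=O)c(/C=C/C(=O)NCc3ccccc3)coc2c1` gives 11800 nM (a number)
Compound 3 `COc1ccc(NC(=O)/C=C/c2coc3cc(O)ccc3c2=O)cc1` gives 12800 nM (a number)

Compound 1 stands at the limit of > 100000 nM in this assay, at which 1 of the 3 values shown sits, and so has a limit rather than a number. Compound 4 `O=C(/C=C/c1coc2cc(O)ccc2c1=O)NCc1ccc(F)cc1F` carries 2,4-difluorophenyl in place of phenyl on a saturated chain carbon bound to an amide-type nitrogen, counted as 2,4-difluorophenyl in place of phenyl on a saturated chain carbon bound to an amide-type nitrogen in full.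

Within the data shown here, no measured step makes this same change. The closest is an at least 7.8-fold lower number from compound 1 to compound 3 (0.89 log units; beyond the scatter), which also alters the group on the amide-type nitrogen. The other is an at least 8.4-fold lower number from compound 1 to compound 2 (0.92 log units; beyond the scatter), made elsewhere in the molecule, so it bears only loosely. Both show that modest changes to compound 1 can give a measurable value.

A lower number is therefore expected in this assay, though a smaller drop than those two, and compound 4 may still reach the limit. The estimated step is an at least 2.5-fold lower number from compound 1 to compound 4 (0.39 log units; beyond the scatter) in this direction. For compound 4 the expected value is 40000 nM, with an estimated range of 12000 nM to 100000 nM overall.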

Compound 4, half-maximal inhibitory concentration: 6610 nM
Estimate against measurement, compound 4: 6.1-fold (0.78 log units) above; the whole stated range lies above it.
By their numbers in this assay, from the lowest: compounds 4, 2 and 3 (each within the scatter of the next). At a limit, above all of these: compound 1.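

In this assay, replacing only the phenyl on a saturated chain carbon bound to an amide-type nitrogen with 2,4-difluorophenyl gives an at least 15-fold lower number from compound 1 to compound 4 (1.17 log units; beyond the scatter). Compound 4 keeps the hydrogen on the oxygen that compound 2 replaces with methyl, and it keeps the saturated chain carbon that compound 3 lacks, so neither of those changes is needed to reach a measurable value. The step can only be stated as a minimum because compound 1 has a limit rather than a number: the limit of > 100000 nM in this assay, at which 1 of the 4 values shown sits.

The compounds shown leave open whether a phenyl carrying a single fluorine would do the same as the two fluorines here, or whether chlorine could take the place of fluorine. They also leave open what happens when 2,4-difluorophenyl is combined with the methyl on the oxygen of compound 2.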